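The compounds below may be only part of what the source reports. "The series", "measured", "known", "first", "only" and "open" are said of these compounds alone.

Compound 1 `COc1ccc(CN(c2cc(OC)c(OC)c(OC)c2)S(=O)(=O)c2ccc(C)cc2)cc1`: 8220 nM
Compound 2 `COc1cc(N(Cc2ccc(Cl)cc2)S(=O)(=O)c2ccc(C)cc2)cc(OC)c1OC`: 14600 nM
Compound 3 `COc1cc(N(Cc2ccc(F)cc2)S(=O)(=O)c2ccc(C)cc2)cc(OC)c1OC`: 20700 nM

These three compounds share one core and were all tested in a functional assay on PC-3 cells (Homo sapiens) for inhibition, read by MTT assay, with a stated time of 48 h; on this read-out higher numbers stand for weaker inhibition and lower numbers for stronger inhibition. Compound 3 gives the highest of the three numbers: the step of a 2.5-fold higher number from compound 1 to compound 3 (0.40 log units; beyond the scatter) is beyond the scatter, while the step of a 1.4-fold higher number from compound 2 to compound 3 (0.15 log units; within the scatter) is within it, so compound 3 and compound 2 cannot be separated on these data.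

Compound 4 `COc1cc(N(Cc2ccc(Br)cc2)S(=O)(=O)c2ccc(C)cc2)cc(OC)c1OC` has not yet been measured. It differs from compound 3 in one place: bromo in place of fluoro on an aromatic carbon. The halogen swaps already seen bear on this change: the step of a 1.4-fold higher number from compound 2 to compound 3 (0.15 log units; within the scatter) was within the scatter, as was the step of a 1.8-fold higher number from compound 1 to compound 2 (0.25 log units; within the scatter). A larger halogen in place of a smaller one therefore gave, at most, a shift inside the usual scatter. The expected step of a 1.5-fold lower number from compound 3 to compound 4 (0.17 log units; within the scatter) in this assay is accordingly small, at most a modest move toward lower numbers. Compound 4 is estimated at 14000 nM, with a range from 6000 nM to 35000 nM.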

Compound 4, half-maximal inhibitory concentration: 4680 nM
Beside the measured number, compound 4's estimate is 3.0-fold (0.48 log units) above it; the measured number lies below the stated range.
By their numbers in this assay, from the lowest: compounds 4, 1, 2 and 3 (each within the scatter of the next, the first and the last beyond it).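

In this assay, bromo on the benzyl ring separates from the lighter halogens, even though compound 2 and compound 3 could not be told apart: fluoro to bromo gives a 4.4-fold lower number from compound 3 to compound 4 (0.65 log units; beyond the scatter) and chloro to bromo gives a 3.1-fold lower number from compound 2 to compound 4 (0.49 log units; beyond the scatter) at the same position. The halogens therefore do not all behave alike here, yet bromo does not clearly outdo methoxy, since a 1.8-fold lower number from compound 1 to compound 4 (0.24 log units; within the scatter) leaves those two compounds inseparable. No measurement shown explains why bromo differs from fluoro and chloro at this position.

Going by these compounds, whether this shift is specific to bromo remains open, and an iodo, methyl or trifluoromethyl group at this position would help to show that. It is also unknown how an amine or a carboxylic acid would behave there.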